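A few compounds are considered here, and "the series" means these few. Any claim that something is new, unique, unknown or untested is made for them only; others in the source may bear on it.

Measured so far:
Compound 1 `CCCOc1ccc(NC(=O)CSc2nnc(Cc3nn(C)c(=O)c4ccccc34)n2C)cc1` gives > 30000 nM, which is a limit of the assay and not a number.
Compound 2 `Cn1c(Cc2nn(C)c(=O)c3ccccc23)nnc1SCCCCCCCCCCC(=O)Nc1ccccc1Cl` gives 15000 nM.
Compound 3 `CC(C)Oc1ccc(NC(=O)CCCCCCCSc2nnc(Cc3nn(C)c(=O)c4ccccc34)n2C)cc1` gives 1100 nM.

These results come from an assay on isolated protein (Mus musculus) for inhibition of IL15-IL15 receptor (Homo sapiens), read by resazurin assay, with stated times of 30 min and 2.5 days; a higher number here means a weaker inhibitor, a lower number a stronger inhibitor. Compound 1 stands only at a limit, as the limit of > 30000 nM in this assay, at which 1 of the 3 values shown sits, records, so no number is known for it. Compound 4 `Cn1c(Cc2nn(C)c(=O)c3ccccc23)nnc1SCC(=O)Nc1ccc(F)cc1F` keeps the shared core and changes only the group on the amide nitrogen, with 2,4-difluorophenyl in place of 4-propoxyphenyl on an amide-type nitrogen. Among the compounds with values here, no measured pair differs in just one place, so the size of this kind of step cannot be read from the data. The step is expected to be small, within the usual scatter: a number no higher from compound 1 to compound 4 (the limit leaves the size open). Compound 4 is therefore estimated at 30000 nM, within 8000 nM to 100000 nM, and a limit rather than a number is quite possible.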

Compound 4, half-maximal inhibitory concentration: "not active" (no number reported)
For compound 4 the study gives words and no number; the estimate stays without a comparison.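

No step can be read between compound 1 and compound 4: compound 4 is reported only as not active, and compound 1 only as a limit. The compounds shown leave open how much the group on the amide nitrogen alone changes inhibition.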